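A few compounds are considered here, and "the series" means these few. Any claim that something is new, unique, unknown or untested is made for them only; others in the source may bear on it.

Measured so far:
compound 1 `Cn1c(-c2noc(C3CCN(C(=O)NC4CCCCC4)CC3)n2)nc2ccccc21` — 89 nM
compound 2 `COc1ccccc1NC(=O)N1CCC(c2noc(-c3ccc4ccccc4n3)n2)CC1` — 2400 nM
compound 3 `O=C(NC1CC[S+]([O-])CC1)N1CCC(c2nc(-c3ccc4ccccc4n3)no2)CC1` — 850 nM

In a functional assay on Shh Light II cells (Mus musculus) for inhibition, read by a luciferase reporter (on this read-out higher numbers stand for weaker inhibition and lower numbers for stronger inhibition), compound 3 gives 850 nM, the second highest of the three numbers; compound 2 lies nearest with a higher number beyond the scatter, and compound 1 lies furthest with a lower number, also beyond the scatter. Compound 4 `Cc1ccccc1NC(=O)N1CCC(c2nc(-c3ccc4ccccc4n3)no2)CC1` is not yet measured. It differs from compound 3 in one place: a group of 7 heavy atoms (7 carbon; one six-membered aromatic ring of carbon only) in place of a group of 7 heavy atoms (5 carbon, 1 oxygen, 1 sulfur; one six-membered non-aromatic ring with 1 hetero atom), on an amide-type nitrogen. For the measured compounds named here, no pair of measured compounds differs only by this change, so the size of the step is open. Compound 2 also carries an aromatic ring of carbon only on the amide-type nitrogen and gives 2400 nM, a higher number than compound 3. In this assay a modest step toward a higher number, beyond the scatter, is expected from compound 3 to compound 4. The expected value for compound 4 is 1500 nM, within 500 nM to 4500 nM. The expected step is a 1.8-fold higher number from compound 3 to compound 4 (0.25 log units; within the scatter).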

Compound 4, half-maximal inhibitory concentration: 440 nM
The estimate for compound 4 lay 3.4-fold (0.53 log units) above the measured number; the whole stated range lies above it.
By their numbers in this assay, from the lowest: compound 1; then compounds 4 and 3 (each within the scatter of the next); then compound 2.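

In this assay, for the compounds shown here, the first step at this amide-type nitrogen, 2-methylphenyl entering for the six-membered non-aromatic ring with its sulfur and oxygen, reads a 1.9-fold lower number from compound 3 to compound 4 (0.29 log units; within the scatter) on the shared core. Here, an aromatic ring of carbon only and the non-aromatic ring with one hetero atom cannot be told apart, even though the hydrogen-bond acceptor count differs. No measurement at hand offers an explanation for this. Still open, from the compounds shown here alone, is whether a plain phenyl, a phenyl bearing a carboxylic acid or an amine, or a longer alkyl chain on this nitrogen would move the number beyond the scatter. A single step also cannot show whether the same tolerance holds on other cores.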